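Cytotoxicity limits across the series; outlook for compound 4

A few compounds are considered here, and "the series" means these few. Any claim that something is new, unique, unknown or untested is made for them only; others in the source may bear on it.

Measured compounds:
compound 1, `Cc1ccc(-c2c3c(nc(C)c2[C@H](OC(C)(C)C)C(=O)O)CCN(c2ccc(-c4ccccc4)cc2)C3)cc1`, > 40000 nM
compound 2, `Cc1ccc(-c2c3c(nc(C)c2C(OC(C)(C)C)C(=O)O)CCN(CCCC2CCCC2)C3)cc1`, > 40000 nM
compound 3, `Cc1nc2c(c(-c3cc(F)c4c(c3C)CCCO4)c1[C@H](OC(C)(C)C)C(=O)O)CN(CCCc1ccc(F)cc1)CC2`, > 40000 nM

In an ADME assay on MT2 cells (Homo sapiens) for cytotoxicity, read by XTT assay, with a stated time of 4 days (a lower number here means that less compound is tolerated, a higher number that more compound is tolerated), compound 1 gives > 40000 nM, which is a limit of the assay and not a number. In this assay compound 2 gives > 40000 nM, also a limit. In this assay compound 3 gives > 40000 nM, again a limit rather than a number. Going by the values given here, no compound can therefore be placed above or below another: every value shown sits at the limit of > 40000 nM in this assay, at which 3 of the 3 values shown sit, and compound 3 stands at that limit together with the other two. Among the compounds with values here, no pair of measured compounds differs in one place only, so no measured step is available.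

Compound 4, `Cc1nc2c(c(-c3cc(F)c4c(c3C)CCCO4)c1[C@H](OC(C)(C)C)C(=O)O)CN(CCCc1ccccc1F)CC2`, has the same atoms as compound 3 joined differently: 2-fluorophenyl in place of 4-fluorophenyl on a saturated chain carbon, three bonds along the chain from an amine nitrogen in a ring. With the three measured compounds all resting at the limit, the step expected in this assay, a step that the limit leaves unreadable from compound 3 to compound 4, is none beyond the scatter. Compound 4 is accordingly expected to give 50000 nM in this assay, within a range of 20000 nM to 150000 nM, and most probably to be reported only as a limit once more.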

Compound 4, half-maximal cytotoxic concentration: > 40000 nM
Compound 4: only a limit was reported (the forecaster's own chance of this, stated with the estimate: 85%); the middle value lies beyond the limit too.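

In this assay, compound 3 and compound 4 are both reported only as limits, so no step between them can be read: the limit of > 40000 nM in this assay, at which 4 of the 4 values shown sit.

The compounds shown leave open at what concentration any of them stops being tolerated, and whether 2-fluorophenyl in place of 4-fluorophenyl changes that concentration at all.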